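A few compounds are considered here, and "the series" means these few. Any claim that something is new, unique, unknown or untested is made for them only; others in the source may bear on it.

Measured so far:
- compound 1 `COc1ccc(CNc2nc([SeH])nc3ccccc23)cc1` — in a functional assay on MCF7 cells (Homo sapiens) for cytotoxicity, read by MTT assay, with a stated time of 72 h (a lower number here means a stronger inhibitor of growth, a higher number a weaker inhibitor of growth), compound 1 gives 42700 nM
- compound 2 `[SeH]c1nc(NCc2ccccc2)c2ccccc2n1` — for compound 2 the result is a limit, > 100000 nM, not a number

Among the compounds with values here, compound 1 is the only one of the pair with a plain number in this assay; the other value is a limit of the assay (the limit of > 100000 nM in this assay, at which 1 of the 2 values shown sits). Within the data shown here, the one measured step, an at least 2.3-fold higher number from compound 1 to compound 2 (0.36 log units; beyond the scatter), concerns the methoxy group on the benzylic ring and nothing else.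

Compound 3 `COc1ccc(CNc2nc(SC)nc3ccccc23)cc1` is not yet measured. It differs from compound 1 at a different site: a group of 2 heavy atoms (1 carbon, 1 sulfur; no ring) in place of one selenium atom, on an aromatic carbon. Among the measured compounds shown here, the step from compound 1 to compound 2 does not touch this position, so it offers no direct guide to the size of the change, and no other measured step covers it. With nothing to point in either direction, the expectation for compound 3 is a number close to that of compound 1, with a step of a 1.2-fold higher number from compound 1 to compound 3 (0.07 log units; within the scatter) that is expected to stay within the usual scatter. Compound 3 is therefore estimated at 50000 nM in this assay, with a range from 15000 nM to 150000 nM.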

Compound 3, concentration for 50% growth inhibition: 30900 nM
Beside the measured number, compound 3's estimate is 1.6-fold (0.21 log units) above it; the measured number falls inside the stated range.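

In this assay, placing methylsulfanyl on the aromatic carbon between two ring nitrogen atoms, where compound 1 carries a selenium atom, gives a 1.4-fold lower number from compound 1 to compound 3 (0.14 log units; within the scatter), so the two compounds cannot be told apart in this read-out. Within the data shown here, this is the first measured change at this position, and it shows that the selenium atom is not needed for the modest growth inhibition seen with compound 1: with sulfur and a methyl carbon in its place, compound 3 still gives a plain number of similar size. The selenium position therefore joins the methoxy group as a second point of comparison in the series, but here the change stays within the scatter, and no measured property shown here offers any explanation for this result.

From the compounds shown here alone, what remains open is whether this position tolerates groups of a different kind, such as an amine, a hydroxyl or a longer chain like butylsulfanyl, since a single step cannot reveal a trend. Also open, going by these compounds, is whether methylsulfanyl gives a similar result without the methoxy group on the benzylic ring.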